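This account rests on a few compounds, and the source may have more. Where it says the series, first, only, none or still open, it means among the compounds named here.

Compound 1, `CN(Cc1cncnc1)S(=O)(=O)c1ccccc1Nc1cc(-c2ccc3ccn(C)c3c2)c2nccnc2c1`: 62 nM 
Compound 2, `Cn1cc(CNC(=O)c2ccncc2Nc2cc(-c3ccc4ccn(C)c4c3)c3nccnc3c2)cn1`: 159 nM 

Both compounds share a core and were read in an assay for inhibition of 6-phosphofructo-2-kinase/fructose-2,6-bisphosphatase 3 (Homo sapiens), read by ADP-Glo, with a stated time of 2 h; on this read-out lower numbers stand for stronger inhibition and higher numbers for weaker inhibition. Of the two numbers, compound 2 carries the higher one: compound 1 gives 62 nM, and compound 2 gives 159 nM, a gap that lies beyond the scatter of repeated measurements. The two structures differ in more than one place, so the gap between them can only be stated, not assigned to any single change.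

Compound 3, `CC(=O)N1CC(NC(=O)c2ccncc2Nc2cc(-c3ccc4ccn(C)c4c3)c3nccnc3c2)C1`, is not yet measured in this assay. It differs from compound 2 in a single place: 1-acetylazetidin-3-yl in place of (1-methyl-1H-pyrazol-4-yl)methyl on an amide-type nitrogen. The amide-type nitrogen and the rest of the molecule are kept. For the measured compounds named here, nothing among the measured compounds tests this kind of change on the amide nitrogen, so there is no step to lean on, and the expectation rests on the small size of the alteration alone. The step expected from compound 2 to compound 3 is a 1.3-fold higher number from compound 2 to compound 3 (0.10 log units; within the scatter), within the scatter in either direction. Compound 3 is therefore estimated at 200 nM, with a range from 70 nM to 600 nM.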

Compound 3, half-maximal inhibitory concentration: 73 nM
Compound 3: the middle estimate sits 2.7-fold (0.44 log units) above what was measured; low and high end bracket the measured number.
By their numbers in this assay, from the lowest: compounds 1 and 3 (each within the scatter of the next); then compound 2.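

For the compounds shown here, the amide-type nitrogen shared by compound 2 and compound 3 gives the first step at a single position: in this assay, 1-acetylazetidin-3-yl in place of (1-methyl-1H-pyrazol-4-yl)methyl gives a 2.2-fold lower number from compound 2 to compound 3 (0.34 log units; beyond the scatter) and so places this position among those where one substituent can be told from another. Both groups have 7 heavy atoms and no net charge, so this pair shows a step beyond the scatter with that count held constant, while a five-membered aromatic ring gives way to a four-membered non-aromatic ring and a double bond outside aromatic rings enters. Nothing measured here on any other property of these compounds offers an explanation for the step.

What remains open is how the step divides between the ring and the acetyl group, since the compounds shown include neither the azetidine with a free amine on its ring nitrogen nor an open-chain acetamide on the amide nitrogen. With one pair at this position, they also leave open whether the same exchange would give a step of similar size on any other compound.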